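The source may report more compounds than this note shows. Statements on the series, on what has been measured and on what is new or still open speak of the compounds shown alone.

Measured so far in a functional assay on SR cells (Homo sapiens) for inhibition, read by sulforhodamine B assay, with a stated time of 48 h, tested at 0.1 uM; a lower number here means a stronger effect, a higher number a weaker effect of the compound at the concentration tested:

Compound 1 `O=C(Nc1cccc(-n2cc(-c3ccncc3)c(-c3cc(O)cc(Cl)c3)n2)c1)Nc1ccc(Cl)c(Cl)c1`: 90%
Compound 2 `COc1cc(Cl)cc(-c2nn(-c3cccc(NC(=O)Nc4ccc(Cl)c(C(F)(F)F)c4)c3)cc2-c2ccncc2)c1`: 92%

The two numbers sit within the scatter of each other, so compound 2 cannot be told apart from compound 1 in this assay; both leave the cells largely unaffected at the tested concentration. Compound 3 `COc1cc(Cl)cc(-c2nn(-c3cccc(NC(=O)Nc4cccc(C(F)(F)F)c4)c3)cc2-c2ccncc2)c1` is not yet measured. It differs from compound 2 by hydrogen in place of chloro on an aromatic carbon. Going by the values given here, no measured step informs this change, and with both known values already near the top of the scale, the expected step of no change at the digits printed from compound 2 to compound 3 (within the scatter) is none beyond the scatter. Compound 3 is therefore estimated at 92%, in the range 80% to 102%.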

Compound 3, a percentage reported as activity, at one concentration (the size of the read-out at that concentration, not a potency): 93%
Estimate against measurement, compound 3: 1 percentage points below; measured number inside the range.
By their numbers in this assay, from the lowest: compounds 1, 2 and 3 (each within the scatter of the next).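

Hydrogen in place of chloro on this aromatic carbon, ortho to a trifluoromethyl group and para to a large group, gives a number 1 percentage points higher from compound 2 to compound 3 (within the scatter) in this assay. Going by these compounds alone, this is the first comparison here between compounds that differ in one place, and it shows that the chloro at this position can go without a change beyond the scatter, with the read-out still high. Nothing available explains this result.

On these data alone, whether an amine or a carboxylic acid on this carbon would lower the number remains open. So does the effect of the trifluoromethyl group taken alone.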